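The source may report more compounds than this note shows. Statements on the series, on what has been measured and on what is new or still open speak of the compounds shown alone.

Measured in a functional assay on K562 cells (Homo sapiens) for cytotoxicity, read by MTT assay; a lower number here means a stronger inhibitor, a higher number a weaker inhibitor:
- compound 1 `COc1ccc(/C=C/C(=O)c2ccc(OC)c3c2OC(C)(C)C=C3)cc1OCC=C(C)C`: > 10000 nM, a limit
- compound 2 `C=CCOc1cc(/C=C/C(=O)c2ccc(OC)c3c2OC(C)(C)C=C3)ccc1OC`: > 10000 nM, a limit
- compound 3 `COc1ccc(/C=C/C(=O)c2ccc(OC)c3c2OC(C)(C)C=C3)cc1OC(=O)C1CC1`: 410 nM

Going by the values given here, compound 3 holds the only true number in this assay, at 410 nM. The other two compounds sit at a limit: the limit of > 10000 nM in this assay, at which 2 of the 3 values shown sit.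

Compound 4 `COc1ccc(/C=C/C(=O)Oc2cc(/C=C/C(=O)c3ccc(OC)c4c3OC(C)(C)C=C4)ccc2OC)cc1` keeps the carbonyl of compound 3 and changes the group on it: 2-(4-methoxyphenyl)ethenyl in place of cyclopropyl on a carbonyl carbon.

Among the compounds with values here, two measured steps bear on this: an at least 24-fold lower number from compound 1 to compound 3 (1.38 log units; beyond the scatter), and an at least 24-fold lower number from compound 2 to compound 3 (1.38 log units; beyond the scatter). Both are large and both bring in the cyclopropylcarbonyl on the oxygen on the aromatic ring. Compound 4 retains a carbonyl on that oxygen, so a fall back to the limit is not the central expectation. Neither step varies the group on the carbonyl carbon, however, so neither gives a direct size for this change, and the range stays wide.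

A moderate move toward a higher number, meaning a weaker inhibitor, is expected: a 3.7-fold higher number from compound 3 to compound 4 (0.56 log units; beyond the scatter). For compound 4 the estimated value is 1500 nM, with an expected range of 300 nM to 8000 nM.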

Compound 4, half-maximal inhibitory concentration: 380 nM
Compound 4: middle estimate off by 3.9-fold (0.60 log units), on the high side; the measured number falls inside the stated range.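

In this assay, 2-(4-methoxyphenyl)ethenyl in place of cyclopropyl on the carbonyl carbon gives a 1.1-fold lower number from compound 3 to compound 4 (0.03 log units; within the scatter), so the entering group of 10 heavy atoms and the leaving group of 3 cannot be told apart here. The gain over the two compounds without a carbonyl on that oxygen therefore appears with a second, quite different carbonyl group: an at least 26-fold lower number from compound 2 to compound 4 (1.42 log units; beyond the scatter), and an at least 26-fold lower number from compound 1 to compound 4 (1.42 log units; beyond the scatter). Compound 1 and compound 2 remain limits, not numbers: the limit of > 10000 nM in this assay, at which 2 of the 4 values shown sit.

Open, on these data alone, is whether a methyl, a longer saturated chain or a chain ending in an amine on the carbonyl carbon would read the same. Also open, as far as these compounds go, is what a free hydroxyl in place of the whole acyl group would give.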